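Bile acid receptor agonists: ethyl to isobutoxy on the core

The source may report more compounds than this note shows. Statements on the series, on what has been measured and on what is new or still open speak of the compounds shown alone.

Three measured compounds share the same aryl ether arm and differ in the fused, acid-bearing core. Compound 1 `CC(C)c1onc(-c2c(Cl)cccc2Cl)c1COc1ccc(-c2ccc3cc(C(=O)O)ncc3c2)cc1` in a functional assay on CV-1 cells for agonist activity at Bile acid receptor (Homo sapiens), read by a luciferase reporter (on this read-out lower numbers stand for an effect already at smaller amounts and higher numbers for an effect only at larger amounts of compound), gives 77 nM. Compound 2 `CC(C)c1onc(-c2c(Cl)cccc2Cl)c1COc1ccc(-c2ccc3nc(C(=O)O)nnc3c2)cc1` carries a different fused core; in this assay compound 2 returns only a limit, > 10000 nM, as recorded in the limit of > 10000 nM in this assay, at which 1 of the 3 values shown sits. Compound 3 `CCc1cc(C(=O)O)nc2ccc(-c3ccc(OCc4c(-c5c(Cl)cccc5Cl)noc4C(C)C)cc3)cc12` carries an ethyl group on its core and in this assay gives 32 nM. Among the two numbers shown, compound 3 stands lowest, with compound 1 above it by a margin that lies beyond the usual scatter; the value of compound 2 is a limit and cannot be ordered against them.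

The next compound, compound 4 `CC(C)COc1cc(C(=O)O)nc2ccc(-c3ccc(OCc4c(-c5c(Cl)cccc5Cl)noc4C(C)C)cc3)cc12`, keeps the core and arm of compound 3 and changes one substituent: isobutoxy in place of ethyl on an aromatic carbon. Within the data shown here, no measured pair in the set isolates this kind of change, so the size of the step is open. With compound 3 at 32 nM as the anchor, the expectation is a step from compound 3 to compound 4 of a 1.3-fold higher number from compound 3 to compound 4 (0.10 log units; within the scatter), either direction, and not clearly beyond the scatter. On that basis compound 4 is estimated at 40 nM in this assay, within a range from 14 nM to 115 nM.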

Compound 4, half-maximal effective concentration: 81 nM
Compound 4: the middle estimate sits 2.0-fold (0.31 log units) below what was measured, and the stated range covers the measured number.
By their numbers in this assay, from the lowest: compound 3; then compounds 1 and 4 (each within the scatter of the next). At a limit, above all of these: compound 2.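

In this assay, among these compounds, isobutoxy in place of ethyl gives a 2.5-fold higher number from compound 3 to compound 4 (0.40 log units; beyond the scatter) and is the first single-place change that can be read. The step is modest, so this aromatic carbon, opposite the ring nitrogen and meta to the carboxy group, takes the longer oxygen-bearing isobutoxy group and still gives a measurable agonist effect, while ethyl remains the better of the two groups compared here. No measurement shown bears on what lies behind the size of this step.

Ethyl and isobutoxy differ both in the oxygen and in the size of the chain, so this single step cannot separate the two, and an ethoxy group or a propyl chain on the same carbon would be needed to tell them apart. Also open, on these data alone, is how an amine or a hydroxyl group would read at this position, and whether a smaller group such as methyl or methoxy would give a number on the same side of ethyl or the other.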